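Swapping the Benzyl Ring Halogens in an Amide Series

A few compounds are considered here, and "the series" means these few. Any claim that something is new, unique, unknown or untested is made for them only; others in the source may bear on it.

Of the compounds shown here, two have been measured so far. Compound 1 `O=C(NCc1ccccc1)c1ccccc1OCc1ccccc1` gives 34200 nM in an assay on lysate for inhibition of phosphatidylcholine:ceramide cholinephosphotransferase 2 (Homo sapiens), read by HPLC, with stated times of 30 min and 2 h (on this read-out lower numbers stand for stronger inhibition and higher numbers for weaker inhibition), while compound 2 `O=C(Nc1cccnc1)c1ccccc1OCc1ccccc1F` gives 3500 nM in this assay. Compound 2 therefore holds the lowest of the two numbers, and the gap to compound 1 lies well beyond the usual scatter of this measurement, so compound 2 is the stronger inhibitor of the pair. Compound 1 and compound 2 differ in more than one place, so their gap cannot be tied to a single change.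

Compound 3 `O=C(Nc1cccnc1)c1ccccc1OCc1cc(F)ccc1Cl` is the next compound to be measured. It differs from compound 2 in one place: 2-chloro-5-fluorophenyl in place of 2-fluorophenyl on a saturated chain carbon bound to an oxygen on an aromatic ring. Among the compounds with values here, no single-change step between two measured compounds is available to guide this prediction, so the expectation rests on compound 2 alone. The step from compound 2 to compound 3 is expected to be small, a 1.4-fold lower number from compound 2 to compound 3 (0.15 log units; within the scatter), and could plausibly fall in either direction or within the scatter. On that basis compound 3 is estimated to give about 2500 nM in this assay, within a range of 800 nM to 8000 nM.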

Compound 3, half-maximal inhibitory concentration: 740 nM
Compound 3: middle estimate off by 3.4-fold (0.53 log units), on the high side; measured number below the stated range.
By their numbers in this assay, from the lowest: compound 3; then compound 2; then compound 1.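

In this assay, putting 2-chloro-5-fluorophenyl in place of 2-fluorophenyl on a saturated chain carbon bound to an oxygen on an aromatic ring gives a 4.7-fold lower number from compound 2 to compound 3 (0.67 log units; beyond the scatter), a modest step but one beyond the scatter. Within the data shown here, this is the first change that can be read on its own, as compound 1 and compound 2 differ in more than one place, and it shows that the substituents on this ring can shift the number even though the rest of the molecule stays the same. Nothing available here explains why this change lowers the number.

The single step combines two differences, an added chlorine and a fluorine in a different place on the ring, so the compounds shown cannot say which of them accounts for the shift, or whether it takes both. Comparing 2-chlorophenyl and 3-fluorophenyl at this place would separate the two, while a methoxy group or a nitrile in place of the chlorine would test whether a halogen is needed there at all.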